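Solubility from an acetyl to a pyrrolidinyl amide

The source may report more compounds than this note shows. Statements on the series, on what has been measured and on what is new or still open speak of the compounds shown alone.

Compound 1 `CCC(=O)c1cc(-c2ccc(Cl)cc2)[nH]c1C`: 900 nM
Compound 2 `CCC(=O)c1cc(-c2ccc(Cl)cc2)n(-c2ccc(S(=O)(=O)N(C)C)cc2)c1C`: 1200 nM
Compound 3 `CC(=O)c1cc(-c2ccc(S(N)(=O)=O)cc2)n(-c2ccc(Cl)cc2)n1`: 86800 nM

The three compounds were measured in a physicochemical assay for solubility, read by HPLC, in phosphate buffer, measured as kinetic solubility, at pH 7.4; on this read-out lower numbers stand for lower solubility and higher numbers for higher solubility. Among them, compound 3 gives the highest number, and its gaps to compound 1 and to compound 2 both lie well beyond the scatter of repeated measurements.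

Compound 4 `NS(=O)(=O)c1ccc(-c2cc(C(=O)N3CCCC3)nn2-c2ccc(Cl)cc2)cc1` has not yet been measured. It differs from compound 3 in one place: pyrrolidin-1-yl in place of methyl on a carbonyl carbon. In words, pyrrolidin-1-yl stands in place of methyl on a carbonyl carbon, which turns acetyl into (pyrrolidin-1-yl)carbonyl.

For the measured compounds named here, no measured pair of compounds differs in just one place, so the data offer no direct guide to this change. With compound 3 at 86800 nM, the top of the three numbers, a new compound has more room to fall than to rise. The estimated step of a 2.9-fold lower number from compound 3 to compound 4 (0.46 log units; beyond the scatter) is therefore a moderate drop in this assay, though it may stay within the scatter. The expected value for compound 4 is 30000 nM, with an estimated range from 8000 nM to 90000 nM.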

Compound 4, solubility: 57900 nM
Compound 4: the middle estimate sits 1.9-fold (0.29 log units) below what was measured, within the range that was stated.
By their numbers in this assay, from the lowest: compounds 1 and 2 (each within the scatter of the next); then compounds 4 and 3 (each within the scatter of the next).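

For the compounds shown here, compound 3 and compound 4 form the first pair here that differs in just one place, so this change can now be read directly. In this assay, putting pyrrolidin-1-yl in place of methyl on a carbonyl carbon gives a 1.5-fold lower number from compound 3 to compound 4 (0.18 log units; within the scatter), which means that a five-membered non-aromatic ring can stand at this spot without a difference larger than repeated measurements would show. Nothing available gives a reason for this outcome.

On these data alone, it remains open whether a carboxylic acid, a dimethylamino group or a six-membered piperidin-1-yl ring on the same carbonyl carbon would also stay within the scatter. A single pair also cannot tell whether the same swap would behave alike on another core, such as the core of compound 1.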